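A few compounds are considered here, and "the series" means these few. Any claim that something is new, unique, unknown or untested is made for them only; others in the source may bear on it.

Measured compounds:
Compound 1, `COc1cc(-c2cc(C(=O)O)c3ccccc3n2)ccc1OCC(=O)Nc1ccccc1C(F)(F)F`: in a physicochemical assay for lipophilicity, using the shake flask method, in phosphate buffer, measured as octanol-water partition, at pH 7.4 (on this read-out higher numbers stand for higher lipophilicity and lower numbers for lower lipophilicity), compound 1 gives 1.3.
Compound 2, `COc1cc(-c2cc(C(=O)O)c3ccccc3n2)ccc1OCC(=O)NCc1ccccc1`: in this assay compound 2 gives 0.4.
Compound 3, `COc1cc(-c2cc(C(=O)O)c3ccccc3n2)ccc1OCC(=O)NCc1cccnc1`: in this assay compound 3 gives -0.8.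

Compound 3 stands lowest of the three numbers. Its nearest neighbour is compound 2, and compound 1 lies furthest from it. The two steps that reach compound 3 are a number 2.10 log units lower from compound 1 to compound 3 (beyond the scatter) and a number 1.20 log units lower from compound 2 to compound 3 (beyond the scatter), both beyond the scatter; the remaining step, a number 0.90 log units lower from compound 1 to compound 2 (beyond the scatter), is the more modest one.

Compound 4, `COc1cc(-c2cc(C(=O)O)c3ccccc3n2)ccc1OCC(=O)NC1CCCCC1`, is not yet measured. It differs from compound 3 in one place: cyclohexyl in place of (pyridin-3-yl)methyl on an amide-type nitrogen. The measured step that bears most directly on this change is a number 1.20 log units lower from compound 2 to compound 3 (beyond the scatter), which exchanged phenyl for pyridin-3-yl on the same saturated chain carbon and was large. The step of a number 0.90 log units lower from compound 1 to compound 2 (beyond the scatter) shows a smaller shift for a different exchange on the amide-type nitrogen. Compound 4 removes the pyridin-3-yl group again and brings in a ring of carbon only, with no hydrogen-bond acceptor, so a step of roughly the size of the phenyl-to-pyridine exchange, in the upward direction, is expected: a number 1.40 log units higher from compound 3 to compound 4 (beyond the scatter). For compound 4 the estimate in this assay is therefore 0.6, with a range from 0 to 1.2.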

Compound 4, distribution coefficient: 0.8
Compound 4: the middle estimate sits 0.20 log units below what was measured, within the range that was stated.
By their numbers in this assay, from the lowest: compound 3; then compound 2; then compound 4; then compound 1.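

In this assay, a saturated ring of carbon only on the amide-type nitrogen does not keep the low number of the (pyridin-3-yl)methyl group, with a number 1.60 log units higher from compound 3 to compound 4 (beyond the scatter) on exchange for cyclohexyl. Cyclohexyl also differs from both groups that carry a carbon-only aromatic ring, with a number 0.40 log units higher from compound 2 to compound 4 (beyond the scatter) against benzyl and a number 0.50 log units lower from compound 1 to compound 4 (beyond the scatter) against 2-(trifluoromethyl)phenyl, so the series now has a saturated ring on this nitrogen that ranks over benzyl and under 2-(trifluoromethyl)phenyl. Nothing at hand explains why these groups rank in this order at this position.

Cyclohexyl differs from benzyl both in the ring and in the chain carbon, so the two contributions remain unseparated; cyclohexylmethyl, which keeps that chain carbon on a saturated ring, would divide them. Going by these compounds, it also remains open whether the large downward step seen with the pyridin-3-yl ring extends to a saturated ring holding nitrogen, such as piperidin-4-yl with its amine, or to a ring holding oxygen, such as tetrahydropyran-4-yl.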